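Aryloxymethyl variation: bromo exchanged for methoxycarbonyl

The source may hold more compounds than are shown below. What is called first, only, known or untested is meant among the compounds shown, and "the series" means these compounds.

Compound 3 `O=c1cc(-n2cc(COc3ccc(Br)cc3)nn2)c2cc(Br)ccc2o1` gives 1920 nM in a functional assay on MCF7 cells (Homo sapiens) for antiproliferative activity, read by MTT assay, with a stated time of 48 h; on this read-out higher numbers stand for weaker inhibition and lower numbers for stronger inhibition. Within the data shown here, it stands lowest of the two numbers measured so far; compound 2 `O=c1cc(-n2cc(COc3cccnc3)nn2)c2cc(Br)ccc2o1` gives 39800 nM, and the step of a 21-fold lower number from compound 2 to compound 3 (1.32 log units; beyond the scatter) lies beyond the scatter. Compound 1 `O=c1cc(-n2cc(CNc3ccccc3)nn2)c2cc(Br)ccc2o1` gives only a limit, > 50000 nM. The step of an at least 26-fold lower number from compound 1 to compound 3 (1.41 log units; beyond the scatter) is likewise large, whereas an at least 1.2-fold lower number from compound 1 to compound 2 (0.09 log units; that floor lies within the scatter) stays within the scatter. Compound 4 `COC(=O)c1ccc(OCc2cn(-c3cc(=O)oc4ccc(Br)cc34)nn2)cc1` differs from compound 3 by methoxycarbonyl in place of bromo on an aromatic carbon. Among the measured compounds shown here, no measured step exchanges one substituent on the phenoxy ring for another; the nearest step, a 21-fold lower number from compound 2 to compound 3 (1.32 log units; beyond the scatter), shows that the aryl group on the oxygen can move the number strongly, so a sizeable shift in either direction remains possible. The expected step for compound 4 is a 2.1-fold higher number from compound 3 to compound 4 (0.32 log units; beyond the scatter), a weakening. Compound 4 is therefore estimated at 4000 nM, between 900 nM and 18000 nM.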

Compound 4, half-maximal inhibitory concentration: 3130 nM
Compound 4: middle estimate off by 1.3-fold (0.11 log units), on the high side, and the stated range covers the measured number.
By their numbers in this assay, from the lowest: compounds 3 and 4 (each within the scatter of the next); then compound 2. At a limit, above all of these: compound 1.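

In this assay, methoxycarbonyl in place of bromo, on an aromatic carbon para to a large group, gives a 1.6-fold higher number from compound 3 to compound 4 (0.21 log units; within the scatter). Among these compounds, this is the first exchange of one substituent for another on the phenoxy ring, and four heavy atoms with two hydrogen-bond acceptors replace one bromine without a step beyond the scatter. Nothing given here bears on why this exchange leaves the number within the scatter.

Still open, on these data alone, is whether a carboxylic acid or an amine at this position would also stay within the scatter of compound 3.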